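This account rests on a few compounds, and the source may have more. Where it says the series, first, only, none or still open, it means among the compounds named here.

Measured compounds:
compound 1, `c1ccc(COc2ccc(OCCOCCNc3ccccc3)cc2)cc1`, gives > 100000 nM
compound 2, `Nc1ccc(COc2ccc(OCCOCCNC3CCCC3)cc2)cc1`, gives 31700 nM

Compound 1 carries an anilino group at the end of its chain. In a functional assay on SK-OV-3 cells (Homo sapiens) for inhibition, read by CCK-8 assay, with a stated time of 70 h (on this read-out lower numbers stand for stronger inhibition and higher numbers for weaker inhibition), compound 1 gives > 100000 nM, and this is a limit of the assay rather than a number, so its true place on the scale is open (the limit of > 100000 nM in this assay, at which 1 of the 2 values shown sits). Compound 2 differs from compound 1 in several places at once. In this assay, going by the values given here, compound 2 gives 31700 nM, a number rather than a limit; since no single step separates the two, only their two values can be set side by side.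

Compound 3, `c1ccc(COc2ccc(OCCOCCNC3CCC3)cc2)cc1`, is the untested compound that follows compound 1 by a single change: cyclobutyl in place of phenyl on an amine nitrogen. Among the compounds with values here, no measured pair shows this exact change, so the size of the step is a guess. Compound 3 is expected to come in at 70000 nM, with a plausible range from 20000 nM to 200000 nM. That estimate means a step from compound 1 to compound 3 of an at least 1.4-fold lower number from compound 1 to compound 3 (0.15 log units; that floor lies within the scatter), and there remains a fair chance that this assay again reports only a limit.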

Compound 3, half-maximal inhibitory concentration: 25000 nM
Compound 3: middle estimate off by 2.8-fold (0.45 log units), on the high side; the measured number falls inside the stated range.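

At this amine nitrogen the group at the end of the chain clearly counts: one change, cyclobutyl in place of phenyl, with the rest of the molecule untouched, gives an at least 4.0-fold lower number from compound 1 to compound 3 (0.60 log units; beyond the scatter) in this assay. Going by these compounds alone, compound 2 could not show this, since it differs from compound 1 in several places at once, so this is the first shift in the set that can be pinned to a single place. The size printed for the step is only a floor, because the value for compound 1 is a limit of the assay and not a number: the limit of > 100000 nM in this assay, at which 1 of the 3 values shown sits.

One pair cannot say whether what matters is the loss of phenyl or the arrival of cyclobutyl, and a cyclohexyl ring or an open chain such as isopropyl on the same nitrogen would help to separate the two. From the compounds shown here alone, it also stays open whether this change would hold on other versions of the core, or in other cell lines.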